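The source may report more compounds than this note shows. Statements on the series, on what has been measured and on what is new or still open speak of the compounds shown alone.

Compound 1 `COc1cc(-c2nnc3n2NC(c2ccco2)C(C(=O)c2ccco2)S3)cc(OC)c1OC` is tested in a functional assay on A549 cells (Homo sapiens) for cytotoxicity, read by MTT assay, with a stated time of 48 h (a higher number here means a weaker inhibitor, a lower number a stronger inhibitor), where compound 1 gives 68700 nM. Compound 2 `COc1cc(-c2nnc3n2NC(c2ccco2)C(C(=O)c2cccs2)S3)cc(OC)c1OC` differs from it in one place, and in this assay compound 2 gives 78700 nM. Among the measured compounds shown here, compound 2 stands alongside compound 1, the only other measured compound, and the gap between them is a 1.1-fold higher number from compound 1 to compound 2 (0.06 log units; within the scatter), so the two cannot be told apart.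

Compound 3 `COc1cc(-c2nnc3n2NC(c2ccco2)C(C(=O)c2ccc(-c4ccccc4)cc2)S3)cc(OC)c1OC` is built from compound 2 by a single change: 4-phenylphenyl in place of thiophen-2-yl on a carbonyl carbon. For the measured compounds named here, the one measured step, a 1.1-fold higher number from compound 1 to compound 2 (0.06 log units; within the scatter), concerns the same carbonyl carbon, where one five-membered ring replaced another and nothing beyond the scatter followed. Going by the values given here, a far larger group enters now, so the step has no close precedent, and no direction can be read from the data. The step from compound 2 to compound 3 is therefore expected to be a 1.0-fold lower number from compound 2 to compound 3 (0.02 log units; within the scatter), within the scatter. Compound 3 is estimated at 75000 nM, in the range 30000 nM to 200000 nM.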

Compound 3, half-maximal inhibitory concentration: > 100000 nM
Compound 3 gave a limit, no number (the forecaster's own chance of this, stated with the estimate: 15%); middle value at least 1.3-fold (0.12 log units) from the limit.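

In this assay, compound 3 gives a limit of the assay rather than a number: the limit of > 100000 nM in this assay, at which 1 of the 3 values shown sits. Among the compounds shown here, this is the first group on this carbonyl carbon that goes beyond a five-membered ring, as 4-phenylphenyl brings two six-membered aromatic rings of carbon only, and the read-out no longer gives an exact value. The change gives an at least 1.2-fold higher number from compound 2 to compound 3 (0.10 log units; that floor lies within the scatter) and an at least 1.4-fold higher number from compound 1 to compound 3 (0.16 log units; that floor lies within the scatter), but both are only floors, so the result shows no gain from the larger group and leaves the true size of the step unknown.

Still open, on these data alone, is whether a single phenyl ring on this carbonyl carbon would give a measurable number. As far as these compounds go, it is also open whether a small methyl group, or a group carrying an amine or a carboxylic acid, would bring the number down.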